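The source may hold more compounds than are shown below. What is called first, only, known or untested is meant among the compounds shown, and "the series" means these compounds.

Measured in a functional assay on the whole organism (strain Sprague-Dawley) for inhibition, with Rattus norvegicus as the target, with a stated time of 10 min; a higher number here means that more compound is needed for the effect, a lower number that less compound is needed:
compound 1 `CCCCOc1ccccc1-c1ncc(C(=O)O)c(=O)[nH]1` gives 0.5 mg/kg
compound 2 `O=C(O)c1cnc(-c2ccccc2OCC2CC2)[nH]c1=O` gives 0.1 mg/kg
compound 3 `CCSc1ccccc1-c1ncc(C(=O)O)c(=O)[nH]1` gives 25 mg/kg

Compound 3 carries the highest number of the three, and its gaps to compound 1 and compound 2 both lie beyond the scatter. The next analogue, compound 4 `C[S+]([O-])c1ccccc1-c1ncc(C(=O)O)c(=O)[nH]1`, is not yet measured. Its difference from compound 3 is a swap of the ethylsulfanyl group on an aromatic carbon (a group of 3 heavy atoms (1 carbon, 1 oxygen, 1 sulfur; no ring) in place of a group of 3 heavy atoms (2 carbon, 1 sulfur; no ring), on an aromatic carbon).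

Within the data shown here, two measured steps concern this same aromatic carbon. Both are large: a 50-fold higher number from compound 1 to compound 3 (1.70 log units; beyond the scatter) and a 250-fold higher number from compound 2 to compound 3 (2.40 log units; beyond the scatter). They show that the number in this assay can move far when the group there changes. Neither step brings in the group carried by compound 4, so they give no direction for this change. The smaller step of a 5.0-fold lower number from compound 1 to compound 2 (0.70 log units; beyond the scatter) shows that even a change within the chain can exceed the scatter.

With no direction available, compound 3 remains the best anchor, and no step beyond the scatter is expected, although the uncertainty is wide in both directions. The expected step is small (a 1.2-fold higher number from compound 3 to compound 4 (0.08 log units; within the scatter)). For compound 4 the estimated value is 30 mg/kg, with an expected range from 6 mg/kg to 120 mg/kg.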

Compound 4, dose for 50% inhibition: > 5 mg/kg
Compound 4 ended at the assay's limit (the forecaster's own chance of this, stated with the estimate: 20%); the middle value does not contradict the limit.
By their numbers in this assay, from the lowest: compound 2; then compound 1; then compound 3.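

In this assay compound 4 stands at a limit of the assay and not at a number: the limit of > 5 mg/kg in this assay, at which 1 of the 4 values shown sits.

The step from compound 3 to compound 4 cannot be read, so this result does not rank the new group against ethylsulfanyl. The steps from the two compounds with an oxygen-linked chain can be read: an at least 50-fold higher number from compound 2 to compound 4 (1.69 log units; beyond the scatter) and an at least 10-fold higher number from compound 1 to compound 4 (1.00 log units; beyond the scatter). On this aromatic carbon, therefore, a second sulfur-bearing group joins ethylsulfanyl on the high side of butoxy and cyclopropylmethoxy, and neither of the four compounds shown goes against this split.

Going by these compounds, the actual number for compound 4 stays open, as does whether any group here without an oxygen-linked chain can reach the low numbers of compound 1 and compound 2. A butylsulfanyl group or a cyclopropylmethylsulfanyl group on the same carbon would separate the linking atom from the length of the chain, and an amine there would test a different kind of link altogether.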